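Thiophene for hydroxyphenyl on the thioester of compound 2

A few compounds are considered here, and "the series" means these few. Any claim that something is new, unique, unknown or untested is made for them only; others in the source may bear on it.

Compound 1 `O=C(SC12CCC(O)C1C(=O)NC2=O)c1ccc(O)cc1` and compound 2 `O=C(S[C@]12CC[C@H](O)[C@H]1C(=O)NC2=O)c1ccc(O)cc1` share one skeleton and differ only in drawn configuration. In an ADME assay on RAW264.7 cells (Mus musculus) for cytotoxicity, read by MTT assay, with a stated time of 24 h (on this read-out lower numbers stand for stronger inhibition and higher numbers for weaker inhibition), compound 1 gives 434000 nM and compound 2 gives 1380000 nM, the highest of the two numbers, a 3.2-fold higher number from compound 1 to compound 2 (0.50 log units; beyond the scatter); the stereo drawing the fact that one of compounds 1 and 2 is drawn with a defined configuration and the other without, at the place where they differ is the only difference there. Compound 3 `O=C(S[C@]12CC[C@H](O)[C@H]1C(=O)NC2=O)c1cccs1` carries thiophen-2-yl in place of 4-hydroxyphenyl on a carbonyl carbon. Going by the values given here, no measured step bears on this aryl swap, so no step beyond the scatter is expected for compound 3: a 1.2-fold lower number from compound 2 to compound 3 (0.06 log units; within the scatter). Compound 3 is expected at 1200000 nM, within 400000 nM to 3000000 nM.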

Compound 3, half-maximal inhibitory concentration: 10900000 nM
For compound 3 the middle estimate is 9.1-fold (0.96 log units) below the measured one, and the stated range ends below it.
By their numbers in this assay, from the lowest: compound 1; then compound 2; then compound 3.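

In this assay, going by these compounds alone, the group on a carbonyl carbon whose other neighbour is sulfur also moves the number, which the earlier compounds, differing only in drawn configuration, could not show: thiophen-2-yl in place of 4-hydroxyphenyl gives a 7.9-fold higher number from compound 2 to compound 3 (0.90 log units; beyond the scatter). The higher number stands for weaker inhibition, so at this position the change weakens the cytotoxic read-out. Nothing in the available evidence bears on why this aryl swap has this effect.

As far as these compounds go, the swap changes the ring and removes the hydroxyl together, so their separate shares stay open. From the compounds shown here alone, how an unsubstituted phenyl, a 4-aminophenyl or a furan-2-yl would read at this position also remains open.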